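Chain length between the aryl ether oxygen and the basic amine

The compounds below may be only part of what the source reports. "The series", "measured", "known", "first", "only" and "open" are said of these compounds alone.

Measured so far:
- compound 1 `O=c1cc(-c2ccccc2)oc2cc(OCc3ccccc3)c(OCCCCN3CCCCC3)c(O)c12`: 2400 nM in a functional assay on HepG2 cells (Homo sapiens) for antiproliferative activity, read by MTT assay, with a stated time of 48 h; a higher number here means a weaker inhibitor, a lower number a stronger inhibitor
- compound 2 `CN1CCN(CCCOc2c(OCc3ccccc3)cc3oc(-c4ccccc4)cc(=O)c3c2O)CC1`: 2400 nM in this assay

Compound 2 stands level with compound 1 at the digits shown; the only measured step, no change at the digits printed from compound 1 to compound 2 (within the scatter), falls within the scatter. Compound 3 `CN1CCN(CCCCOc2c(OCc3ccccc3)cc3oc(-c4ccccc4)cc(=O)c3c2O)CC1` differs from compound 2 by (4-methylpiperazin-1-yl)methyl in place of 4-methylpiperazin-1-yl on a saturated chain carbon, three bonds along the chain from an oxygen on an aromatic ring, that is, the chain carrying the amine grows by one carbon. Among the measured compounds shown here, no measured pair isolates this change; the step from compound 1 to compound 2 swaps amine and chain length together and reads as no change. Compound 1 already carries the four-carbon chain that compound 3 has, with a different amine, and sits where compound 2 sits. A step of no size beyond the scatter is therefore expected in this assay. Compound 3 is estimated at 2400 nM, range 1200 nM to 4800 nM, so that the expected step of no change at the digits printed from compound 2 to compound 3 (within the scatter) is flat.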

Compound 3, half-maximal inhibitory concentration: 2500 nM
Compound 3: the middle estimate sits 1.0-fold (0.02 log units) below what was measured; measured number inside the range.
By their numbers in this assay, from the lowest: compounds 1, 2 and 3 (each within the scatter of the next).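

In this assay, the change from 3-(4-methylpiperazin-1-yl)propyl to 4-(4-methylpiperazin-1-yl)butyl now stands alone, with the amine held constant, and gives a 1.0-fold higher number from compound 2 to compound 3 (0.02 log units; within the scatter) as a flat step. The amine change also stands alone: 4-methylpiperazin-1-yl in place of piperidin-1-yl, four bonds along the chain from an oxygen on an aromatic ring, gives a 1.0-fold higher number from compound 1 to compound 3 (0.02 log units; within the scatter) and is likewise flat, so the two changes mixed in the earlier step are now read separately. No supporting measurement on hand bears on these flat steps.

Still open, from the compounds shown here alone, is whether a 2-(4-methylpiperazin-1-yl)ethyl chain or a longer hexyl chain would hold this level. Also open, going by these compounds, is how morpholine or dimethylamino would read at the chain end, or a carboxylic acid in place of the amine.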